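The compounds below may be only part of what the source reports. "The series", "measured", "known", "first", "only" and "open" are said of these compounds alone.

Three compounds of the series have been measured in a functional assay on spleen for antagonist activity at Alpha-1B adrenergic receptor (Rattus norvegicus); a lower number here means a less potent compound, a higher number a more potent compound, by a factor of ten per unit of this negative logarithm:

Compound 1 `COc1ccccc1N1CCN(CC2=NS(=O)(=O)c3ccc(C)cc3N2)CC1`: compound 1 gives 6.05.
Compound 2 `COc1ccccc1N1CCN(CC2=NS(=O)(=O)c3ccc(Cl)cc3N2)CC1`: compound 2 gives 6.17.
Compound 3 `COc1ccccc1N1CCN(CC2Nc3cc(C)ccc3S(=O)(=O)N2)CC1`: compound 3 gives 6.24.

Among the compounds with values here, the one counted step lies between compound 1 and compound 2, (chloro in place of methyl on an aromatic carbon), and amounts to a number 0.12 log units higher from compound 1 to compound 2 (within the scatter). Compound 3 carries a different core from compound 1; the difference between the two cores is not broken down here, and the two values stand within the scatter of each other.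

Compound 4 `COc1ccccc1N1CCN(CC2Nc3cc(Cl)ccc3S(=O)(=O)N2)CC1` is not yet measured. Relative to compound 3 it carries the same change, (chloro in place of methyl on an aromatic carbon), with the same surroundings as in the change from compound 1 to compound 2. The step is therefore expected to repeat: compound 4 is expected to move by a number 0.12 log units higher from compound 3 to compound 4 (within the scatter) in this assay, resting on the step of a number 0.12 log units higher from compound 1 to compound 2 (within the scatter). Compound 4 is estimated at 6.36, with the expected range running from 6 to 6.7.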

Compound 4, negative logarithm of the antagonist equilibrium constant: 5.09
Compound 4: the middle estimate sits 1.27 log units above what was measured; measured number below the stated range.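

In this assay, chloro in place of methyl on an aromatic carbon gives a number 1.15 log units lower from compound 3 to compound 4 (beyond the scatter). Set beside the earlier step, this change does not carry over unchanged from one core to the other: the same change on two cores in this assay, a number 0.12 log units higher (within the scatter) from compound 1 to compound 2 and a number 1.15 log units lower (beyond the scatter) from compound 3 to compound 4, 1.27 log units apart, beyond the scatter of two such steps. This shows that the step depends on the core for these two pairs, but with one pair per core it neither gives a cause nor predicts the step on any further core.

Still open, from the compounds shown here alone, is whether the drop on the core of compound 3 is particular to chloro. Fluoro or an amine on the same aromatic carbon of both cores would test this.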